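This account rests on a few compounds, and the source may have more. Where it says the series, first, only, none or still open, it means among the compounds named here.

Going by the values given here, compound 1 `COC(=O)c1c(Nc2ccccc2)sc(C(=O)c2ccc(OC)cc2)c1C` is the only compound of this set with a reported number. In a functional assay, with a stated time of 150 min, tested at 20 ug/mL (a lower number here means a weaker effect, a higher number a stronger effect of the compound at the concentration tested), compound 1 gives 32.4%, a moderate effect at the single concentration tested. Among the compounds with values here, compound 2 `COC(=O)c1c(Nc2ccc(Cl)cc2)sc(C(=O)c2ccc(OC)cc2)c1C` was tested in this assay as well, and compound 2 is reported as "not active" (no number reported), without a number, so no step between measured compounds can be drawn from it. Compound 3 `COC(=O)c1c(Nc2ccccc2)sc(C(=O)c2ccc(C)cc2)c1C` is not yet measured; it differs from compound 1 by methyl in place of methoxy on an aromatic carbon. Without any measured step to lean on, the change of methyl in place of methoxy on an aromatic carbon is expected to move the read-out only a little, and the step from compound 1 to compound 3 is estimated at a number 6.4 percentage points lower from compound 1 to compound 3 (within the scatter), slightly downward but possibly within the scatter. Compound 3 is therefore expected to give 26% in this assay, with a range from 8% to 44%.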

Compound 3, a percentage reported as activity, at one concentration (the size of the read-out at that concentration, not a potency): 6.06%
Beside the measured number, compound 3's estimate is 19.9 percentage points above it; measured number outside the range, below it.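

In this assay, going by these compounds alone, the change from 4-methoxyphenyl to 4-methylphenyl gives the first readable step in this set, a number 26.3 percentage points lower from compound 1 to compound 3 (beyond the scatter). The place para to a large group is therefore not indifferent to what it carries: with the shared core otherwise unchanged, exchanging methoxy for methyl is enough to produce a step beyond the scatter. No available measurement gives a reason for this step.

The compounds shown leave open how this place would respond to a hydroxyl group, an ethoxy group or an amine, and whether a plain hydrogen there would read closer to compound 1 or to compound 3. They also leave open whether the same step would hold alongside the chloro substituent of compound 2, which has no reported number.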